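The compounds below may be only part of what the source reports. "The series", "measured", "known", "first", "only" and "open" are said of these compounds alone.

Compound 1, `O=C(NCCCCc1ccccc1)c1cccc(C2SCC(=O)N2c2cccc(-c3c[nH]nn3)c2)c1`, gives 110 nM in a functional assay on HOS-TE85 cells (Homo sapiens) for inhibition, read by CCK-8 assay, with a stated time of 72 h; on this read-out higher numbers stand for weaker inhibition and lower numbers for stronger inhibition.
Compound 2, `COc1ccc(F)cc1N1C(=O)CSC1c1cccc(C(=O)NCCCCn2cccn2)c1`, gives 97.3 nM in this assay.
Compound 3, `COc1ccccc1N1C(=O)CSC1c1cccc(C(=O)NCCCCn2cccn2)c1`, gives 91.7 nM in this assay.

All three compounds share a core and differ only in the substituents on one aromatic ring of that core. Compound 1 has the highest of the three numbers, but its gap to compound 2 and to compound 3 lies within the scatter, so none of the three can be called stronger or weaker than another. For the measured compounds named here, the only single-point step among them, a 1.1-fold lower number from compound 2 to compound 3 (0.03 log units; within the scatter), is likewise within the scatter.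

Compound 4, `C#Cc1cccc(N2C(=O)CSC2c2cccc(C(=O)NCCCCc3ccccc3)c2)c1`, is derived from compound 1 by one change: ethynyl in place of 1H-1,2,3-triazol-4-yl on an aromatic carbon. Going by the values given here, no measured step replaces a ring with a chain on that aromatic carbon, so the step from compound 2 to compound 3 does not bear on it directly. What the data do show is that quite different groups on that ring, in compound 1, compound 2 and compound 3, all give numbers within the scatter of one another. On that basis compound 4 is expected to land close to compound 1, with a 1.1-fold higher number from compound 1 to compound 4 (0.04 log units; within the scatter), meaning no shift beyond the scatter. The estimate for compound 4 in this assay is 120 nM, within a range from 50 nM to 300 nM.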

Compound 4, half-maximal inhibitory concentration in the HOS-TE85 assay: 149 nM
For compound 4 the middle estimate is 1.2-fold (0.09 log units) below the measured one; low and high end bracket the measured number.
By their numbers in the HOS-TE85 assay, from the lowest: compounds 3, 2, 1 and 4 (each within the scatter of the next).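

The pair of compound 1 and compound 4 is the first one shown that isolates this position, meta to a large group. In the HOS-TE85 assay, ethynyl in place of 1H-1,2,3-triazol-4-yl gives (a 1.4-fold higher number from compound 1 to compound 4 (0.13 log units; within the scatter)), so on this read-out a small group with no ring and 0 hydrogen-bond donors cannot be told apart from a five-membered aromatic ring with 1 hydrogen-bond donor and 2 hydrogen-bond acceptors. The same change can also be followed in a second measurement: in a physicochemical assay for solubility, read by turbidimetry, measured as kinetic solubility, at pH 6.8 (a lower number here means a less soluble compound, a higher number a more soluble compound), compound 1 gives 20000 nM and compound 4 gives 10000 nM (a 2.0-fold lower number from compound 1 to compound 4 (0.30 log units; within the scatter)), so neither read-out separates the two groups, and no measurement at hand offers an explanation for this.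

Going by these compounds, whether an amine, a carboxylic acid or a longer chain on this aromatic carbon would move either number beyond the scatter remains open. On these data alone, it is also open whether the same swap would give a similar result on a compound carrying the other chain seen in compound 3.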